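Stripping the side chain from compound 2

The compounds below may be only part of what the source reports. "The series", "measured", "known", "first", "only" and "open" are said of these compounds alone.

In a functional assay on HCT-116 cells (Homo sapiens) for cytotoxicity, read by MTT assay, with a stated time of 72 h (on this read-out higher numbers stand for weaker inhibition and lower numbers for stronger inhibition), compound 1 (`O=C(NCc1ccc(F)cc1)c1nc(Br)c2cccnc2c1NCc1ccc(F)cc1`) gives > 20000 nM as its reading, which is a limit of the assay and not a number. Compound 2 (`O=C(NCCCNc1c(C(=O)NCc2ccc(F)cc2)nc(Br)c2cccnc12)c1ccccc1`) gives > 10000 nM as its reading, and this too is only a limit. Compound 3 (`CNc1c(C(=O)NCc2ccc(F)cc2)nc(Br)c2cccnc12`) differs from compound 2 as counted here: hydrogen in place of 2-benzamidoethyl on a saturated chain carbon bound to a nitrogen on an aromatic ring; in words, hydrogen in place of 2-benzamidoethyl on a saturated chain carbon bound to a nitrogen on an aromatic ring. Among the measured compounds shown here, the one measured step at this place, a step that the two limits leave unreadable from compound 1 to compound 2 in the data, has no readable size, so it offers nothing to carry over. No step beyond the scatter is therefore expected in this assay and no direction can be named. The estimated step is a step that the limit leaves unreadable from compound 2 to compound 3 for now. Compound 3 is expected at 20000 nM with a range from 6000 nM to 60000 nM in this estimate, and it may well be reported only as a limit.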

Compound 3, half-maximal inhibitory concentration: > 20000 nM
Compound 3: only a limit was reported; the forecaster's own chance of this, stated with the estimate: 80%; the middle value sits exactly at the limit.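

In this assay, among the compounds shown here, compound 1, compound 2 and compound 3 all stop at limits of the assay, so no step among them can be read: the limit of > 20000 nM in this assay, at which 2 of the 3 values shown sit. The compounds shown leave open whether any side chain on the shared core can give a measurable reading.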